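Replacing the aryl urea of compound 3: notes on compound 4

The compounds below may be only part of what the source reports. "The series", "measured", "known", "first", "only" and "open" are said of these compounds alone.

Measured compounds:
compound 1, `COc1cc(Nc2ncnc3c(NC(=O)Nc4ccc(C)cc4C)cccc23)cc(OC)c1`: 1290 nM
compound 2, `COc1cc(Nc2ncnc3c(NC(=O)Nc4ccc([N+](=O)[O-])cc4)cccc23)cc(OC)c1`: a limit of the assay, > 20000 nM
compound 3, `COc1cc(Nc2ncnc3c(NC(=O)Nc4cc(C)cc(C)c4)cccc23)cc(OC)c1`: 10100 nM

In a functional assay on RT-112 cells (Homo sapiens) for antiproliferative activity, read by MTT assay, with a stated time of 72 h (on this read-out higher numbers stand for weaker inhibition of growth and lower numbers for stronger inhibition of growth), compound 1 gives 1290 nM. Compound 3 gives 10100 nM, the highest of the two numbers shown. For compound 2 the measurement stops at a limit of the assay, > 20000 nM, so it is not a number. Among the steps, a 7.8-fold higher number from compound 1 to compound 3 (0.89 log units; beyond the scatter) and an at least 15-fold higher number from compound 1 to compound 2 (1.19 log units; beyond the scatter), while an at least 1.9-fold lower number from compound 2 to compound 3 (0.29 log units; that floor lies within the scatter), so compound 2 and compound 3 cannot be ordered.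

Compound 4 is `COc1cc(Nc2ncnc3c(NC(=O)c4cc(=O)c5ccccc5o4)cccc23)cc(OC)c1`. The change is a group of 11 heavy atoms (9 carbon, 2 oxygen; one six-membered aromatic ring of carbon only, one six-membered aromatic ring with 1 hetero atom) in place of a group of 9 heavy atoms (8 carbon, 1 nitrogen; one six-membered aromatic ring of carbon only), on a carbonyl carbon. All measured steps exchange one aryl group for another on the amide-type nitrogen and leave the arylamino unit in place; none removes it, so they bear on this step only loosely. Within the data shown here, the numbers seen span from compound 1 to the limit of compound 2, with compound 3 between, and there is no step of this kind to anchor a direction. The expectation for compound 4 is therefore no step beyond the scatter, a 1.3-fold lower number from compound 3 to compound 4 (0.10 log units; within the scatter), with a wide range. Compound 4 is estimated at 8000 nM, between 1500 nM and 30000 nM.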

Compound 4, concentration for 50% growth inhibition: > 20000 nM
Compound 4: a limit, no number (the forecaster's own chance of this, stated with the estimate: 30%); middle value at least 2.5-fold (0.39 log units) away from the limit.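

In this assay compound 4 gives > 20000 nM, a limit of the assay and not a number: the limit of > 20000 nM in this assay, at which 2 of the 4 values shown sit.

This is the first change shown that takes out the (3,5-dimethylphenyl)amino unit rather than swapping one aryl group for another, and it gives an at least 15-fold higher number from compound 1 to compound 4 (1.19 log units; beyond the scatter), so the entering group on the carbonyl carbon does not hold the level reached by the 2,4-dimethylphenyl urea of compound 1. The other readable step, an at least 1.9-fold higher number from compound 3 to compound 4 (0.29 log units; that floor lies within the scatter), has a floor within the scatter and does not establish a loss against the 3,5-dimethylphenyl urea; compound 2 and compound 4 both stand at limits, so the step between them cannot be read.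

The change swaps the amide-type nitrogen and the aryl group together, and the compounds shown do not separate the two, so it remains open whether the nitrogen or the entering ring system accounts for the result. Also open, from the compounds shown here alone, is how a saturated amine such as morpholine or piperidine on the same carbonyl carbon, or a 2,4-dimethylphenyl group set directly on it, would read in this assay.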